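The compounds below may be only part of what the source reports. "The series", "measured", "known", "first", "only" and "open" are said of these compounds alone.

In an ADME assay on HepG2 cells (Homo sapiens) for cytotoxicity, read by luminescence, CellTiter-Glo and ATP content, with a stated time of 72 h (on this read-out lower numbers stand for an effect already at smaller amounts and higher numbers for an effect only at larger amounts of compound), compound 1 `COc1ccc(-c2ccc3c(NCCCNCc4cccc(OC)c4O)ccnc3c2)cc1` gives 1600 nM as the lowest of three numbers, while compound 2 `Cc1cc(C)cc(Cc2ccc3c(NCCCNCc4ccco4)ccnc3c2)c1` gives 6270 nM and compound 3 `COc1cccc(Oc2ccc3c(NCCCNCc4cc(F)ccc4OC)ccnc3c2)c1` gives 7100 nM in the same read-out. Both gaps from compound 1 lie beyond the scatter. Compound 4 `COc1cccc(CNCCCNc2ccnc3cc(CCC(C)C)ccc23)c1O` has no number yet: it carries isopentyl in place of 4-methoxyphenyl on an aromatic carbon of the core of compound 1 isopentyl in place of 4-methoxyphenyl on an aromatic carbon and is otherwise the same. Going by the values given here, no measured pair isolates a change at this place, so the expectation rests only on these three numbers and remains loose. In this assay a small upward step is expected, with a 1.8-fold higher number from compound 1 to compound 4 (0.24 log units; within the scatter) as the estimate, not clearly beyond the scatter. For compound 4 the estimated value is 2800 nM with an expected range from 1000 nM to 7500 nM on this read-out.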

Compound 4, half-maximal effective concentration: 5390 nM
For compound 4 the middle estimate is 1.9-fold (0.28 log units) below the measured one, and the stated range covers the measured number.
By their numbers in this assay, from the lowest: compound 1; then compounds 4, 2 and 3 (each within the scatter of the next).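

Isopentyl in place of 4-methoxyphenyl on this aromatic carbon is the only step at this place in this assay and gives a 3.4-fold higher number from compound 1 to compound 4 (0.53 log units; beyond the scatter), so the number here does respond to the group carried on the shared core. An open chain with no ring does not reproduce the result of the 4-methoxyphenyl group. Nothing at hand accounts for this step.

Still open, as far as these compounds go, is whether the step follows the loss of the ring or of the methoxy oxygen, which a plain phenyl group would help separate. From the compounds shown here alone, a carboxylic acid or an amine at this place, and the same exchange on other side chains, also remain unexplored.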